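Swapping Cyclohexyl for Phenyl on a Second Core

This account rests on a few compounds, and the source may have more. Where it says the series, first, only, none or still open, it means among the compounds named here.

Of the compounds shown here, three built on a shared core have been measured in a functional assay on cells (Homo sapiens) for cytotoxicity, read by MTT assay, with a stated time of 72 h; a higher number here means a weaker inhibitor, a lower number a stronger inhibitor. Compound 1 `Cc1ccc(C)c(COc2cc(NC(=O)C3CCCCC3)ccc2N(C)S(C)(=O)=O)c1` gives 2660 nM. Compound 2 `Cc1ccc(C)c(COc2cc(NC(=O)c3ccccc3)ccc2N(C)S(C)(=O)=O)c1` gives 4680 nM. Compound 3 `CC(C)c1ccc(COc2cc(NC(=O)C3CCCCC3)ccc2N(C)S(C)(=O)=O)cc1` gives 16100 nM, the highest number of the three. Compound 1 and compound 2 differ by phenyl in place of cyclohexyl on a carbonyl carbon, and this change made a 1.8-fold higher number from compound 1 to compound 2 (0.25 log units; within the scatter). The cores of compound 1 and compound 3 differ by 4-isopropylphenyl in place of 2,5-dimethylphenyl on a saturated chain carbon bound to an oxygen on an aromatic ring, a change that made a 6.1-fold higher number from compound 1 to compound 3 (0.78 log units; beyond the scatter). Compound 4 `CC(C)c1ccc(COc2cc(NC(=O)c3ccccc3)ccc2N(C)S(C)(=O)=O)cc1` has not yet been measured in this assay. It differs from compound 3 by phenyl in place of cyclohexyl on a carbonyl carbon, the same change that turned compound 1 into compound 2, made at the same place. Compound 4 is expected to show a 1.7-fold higher number from compound 3 to compound 4 (0.22 log units; within the scatter), close to the earlier step, because that step gave a 1.8-fold higher number from compound 1 to compound 2 (0.25 log units; within the scatter) and nothing among these compounds suggests the change behaves differently on the core of compound 3. Compound 4 is therefore estimated at 27000 nM in this assay, with a likely range from 11000 nM to 65000 nM.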

Compound 4, half-maximal inhibitory concentration: 7930 nM
Beside the measured number, compound 4's estimate is 3.4-fold (0.53 log units) above it; the whole stated range lies above it.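

In this assay, phenyl in place of cyclohexyl on a carbonyl carbon gave a 2.0-fold lower number from compound 3 to compound 4 (0.31 log units; beyond the scatter), so the swap did not carry over from the core of compound 1 with the same size or direction: the same change on two cores in this assay, a 1.8-fold higher number (0.25 log units; within the scatter) from compound 1 to compound 2 and a 2.0-fold lower number (0.31 log units; beyond the scatter) from compound 3 to compound 4, 3.6-fold (0.55 log units) apart, beyond the scatter of two such steps

The same square of four compounds can be read the other way, and 4-isopropylphenyl in place of 2,5-dimethylphenyl gave a 1.7-fold higher number from compound 2 to compound 4 (0.23 log units; within the scatter), a step that also depends on what the other end of the molecule holds: the same change on two cores in this assay, a 6.1-fold higher number (0.78 log units; beyond the scatter) from compound 1 to compound 3 and a 1.7-fold higher number (0.23 log units; within the scatter) from compound 2 to compound 4, 3.6-fold (0.55 log units) apart, beyond the scatter of two such steps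

This shows that, among these four compounds, the two changes do not act independently, so a step measured on one core cannot simply be added to another; it does not show why, and one square cannot say how widely this holds across the series.

As far as these compounds go, it remains open how other groups on the carbonyl carbon would behave, such as a longer chain or a ring carrying an amine. Whether a carboxylic acid on the benzyl ring would follow the same mismatch also stays unanswered.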